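A few compounds are considered here, and "the series" means these few. Any claim that something is new, unique, unknown or untested is made for them only; others in the source may bear on it.

Compound 1, `CCCCCCCCS(=O)(=O)Nc1ccc(-c2cccc(Cl)c2)cc1C(=O)O`: 8900 nM
Compound 2, `CCCCCCCCS(=O)(=O)Nc1cc(/C=C/c2ccccc2)ccc1C(=O)O`: 38000 nM

Both compounds were tested in an assay on mitochondria (strain BALB/c) for inhibition of glycerol-3-phosphate acyltransferase 1, mitochondrial (Mus musculus), read by scintillation counting, with a stated time of 10 min; on this read-out higher numbers stand for weaker inhibition and lower numbers for stronger inhibition. Of the two, compound 1 has the lower number, and compound 2 sits at a higher number, a gap beyond the usual scatter of this measurement. These two compounds differ in more than one place, so their pair says nothing about what any single change does on its own.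

Compound 3, `CCCCCCCCS(=O)(=O)Nc1ccc(/C=C/c2ccc(OC)cc2)cc1C(=O)O`, has not yet been measured. It differs from compound 1 in one place: 2-(4-methoxyphenyl)ethenyl in place of 3-chlorophenyl on an aromatic carbon. Among the measured compounds shown here, no measured pair here isolates this exchange of a 3-chlorophenyl for a 2-(4-methoxyphenyl)ethenyl, so the expectation rests on the number of compound 1 and on the size of steps that such an exchange usually brings. A step of a 1.7-fold higher number from compound 1 to compound 3 (0.23 log units; within the scatter) is expected, a modest move toward a higher number that may well stay within the scatter. Compound 3 is therefore expected to give about 15000 nM, with a plausible range from 5000 nM to 50000 nM.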

Compound 3, half-maximal inhibitory concentration: 37100 nM
Compound 3: middle estimate off by 2.5-fold (0.39 log units), on the low side; the measured number falls inside the stated range.
By their numbers in this assay, from the lowest: compound 1; then compounds 3 and 2 (each within the scatter of the next).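

In this assay, putting 2-(4-methoxyphenyl)ethenyl in place of 3-chlorophenyl on this aromatic carbon, para to a large group and meta to a carboxy group, brings a 4.2-fold higher number from compound 1 to compound 3 (0.62 log units; beyond the scatter), which means weaker inhibition. Among the compounds shown here, this is the first reading of a single change at this place, and it shows that the number responds to which group sits there, since the step lies beyond the usual scatter. The exchange alters several things at once, as the chlorine leaves while a double bond outside the ring and a methoxy oxygen enter, and nothing measured here gives a reason for the step.

Which of these parts carries the step stays open: a plain phenyl, or a 4-methoxyphenyl joined directly to the shared core, would help separate the part played by the double bond from that of the groups on the ring. Also open, from the compounds shown here alone, is whether a different kind of group on this carbon, such as an amine or a second carboxylic acid, would give a lower number than compound 1 does.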